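The source may report more compounds than this note shows. Statements on the series, on what has been measured and on what is new or still open speak of the compounds shown alone.

Measured compounds:
compound 1 `CCn1c(SCC(=O)c2ccccc2)nnc1-c1ccc(OC)cc1`: 53%
compound 2 `COc1ccc(-c2nnc(SCC(=O)c3ccccc3)n2-c2ccccc2)cc1OC`: 56%
compound 3 `CCn1c(SC/C(=N/O)c2ccccc2)nnc1-c1ccc(OC)c(OC)c1`: 61%

All three were tested in a functional assay on the whole organism (strain albino) for inhibition, with Rattus norvegicus as the target, read by paw edema, with a stated time of 1 h, at a dose of 0.28 mmol/kg by the oral route; on this read-out higher numbers stand for more inhibition at the one dose given (going by the name of the read-out) and lower numbers for less inhibition. Compound 3 gives the highest of the three numbers, but compound 2 and compound 1 lie within the usual scatter of it, so the three cannot be ranked.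

Compound 4 `CCn1c(SCC(=O)c2ccccc2)nnc1-c1ccc(OC)c(OC)c1` is the unmeasured analogue of compound 3. The change is a group of 8 heavy atoms (7 carbon, 1 oxygen; one six-membered aromatic ring of carbon only) in place of a group of 9 heavy atoms (7 carbon, 1 nitrogen, 1 oxygen; one six-membered aromatic ring of carbon only), on a saturated chain carbon bound to a sulfur. The group that enters is a benzoyl, and the place is a saturated chain carbon bound to a sulfur. Among the compounds with values here, no single-change step between measured compounds exists to size this change; compound 1 also carries a benzoyl there and gives a value within the scatter of compound 3.

Compound 4 is therefore expected to give 55%, between 44% and 66%. The step of a number 6 percentage points lower from compound 3 to compound 4 (within the scatter) is estimated to stay within the scatter.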

Compound 4, a percentage reported as inhibition, in the whole organism at one dose (the size of the read-out at that dose, not a potency): 42%
Beside the measured number, compound 4's estimate is 13 percentage points above it; the measured number lies below the stated range.
By their numbers in this assay, from the lowest: compound 4; then compounds 1, 2 and 3 (each within the scatter of the next).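

In this assay, single changes can now be sized, and each one lowers the number beyond the scatter: benzoyl entering on the saturated chain carbon bound to a sulfur gives a number 19 percentage points lower from compound 3 to compound 4 (beyond the scatter), ethyl in place of phenyl on an aromatic nitrogen gives a number 14 percentage points lower from compound 2 to compound 4 (beyond the scatter), and methoxy in place of hydrogen on an aromatic carbon gives a number 11 percentage points lower from compound 1 to compound 4 (beyond the scatter). The group on that chain carbon therefore counts, and losing its hydrogen-bond donor goes with the largest of these steps, although all three are modest. Nothing available explains these drops. Going by these compounds, whether an amine or a carboxylic acid on that chain carbon would restore the inhibition remains open. So does the effect of a longer chain in place of ethyl on the aromatic nitrogen.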